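From compound 2 to compound 3

The source may hold more compounds than are shown below. What is called first, only, known or untested is meant among the compounds shown, and "the series" means these compounds.

Measured in a physicochemical assay for solubility (on this read-out higher numbers stand for higher solubility and lower numbers for lower solubility), so far:
- compound 1 `O=C(CN1CCCC1)N1CCC(NS(=O)(=O)c2cc(S(=O)(=O)c3ccccc3)ccc2C(F)(F)F)CC1` at 25000 nM
- compound 2 `O=C1CC[C@@H](C(=O)N2CCC(NS(=O)(=O)c3cc(S(=O)(=O)c4ccccc4)ccc3C(F)(F)F)CC2)N1` at 100000 nM

Compound 2 stands highest of the two measured compounds. Among the measured compounds shown here, one measured step bears on the change ahead, at a carbonyl carbon: a 4.0-fold higher number from compound 1 to compound 2 (0.60 log units; beyond the scatter) is modest in size. Compound 3 `CC(C)C(=O)N1CCC[C@H]1C(=O)N1CCC(NS(=O)(=O)c2cc(S(=O)(=O)c3ccccc3)ccc2C(F)(F)F)CC1` carries 1-(isopropylcarbonyl)pyrrolidin-2-yl in place of 5-oxopyrrolidin-2-yl on a carbonyl carbon. For the measured compounds named here, no measurement yet covers this group, so the direction is only tentative. With compound 1 at 25000 nM as the sole lower reference, a modest fall of similar size is expected. The estimated step is a 2.9-fold lower number from compound 2 to compound 3 (0.46 log units; beyond the scatter) in this assay on this reading. The expected value for compound 3 is 35000 nM as a central estimate (range 12000 nM to 100000 nM).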

Compound 3, solubility: 100000 nM
The estimate for compound 3 lay 2.9-fold (0.46 log units) below the measured number, within the range that was stated.
By their numbers in this assay, from the lowest: compound 1; then compounds 2 and 3 (each within the scatter of the next).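

At this carbonyl carbon, this assay shows no change at the digits printed from compound 2 to compound 3 (within the scatter) even though 1-(isopropylcarbonyl)pyrrolidin-2-yl brings 10 heavy atoms in place of 6 and 0 hydrogen-bond donors in place of 1. Within this pair, then, the number holds across both of those differences in the group. The earlier step away from (pyrrolidin-1-yl)methyl also now has a second example, a 4.0-fold higher number from compound 1 to compound 3 (0.60 log units; beyond the scatter) in this assay, so it is no longer tied to 5-oxopyrrolidin-2-yl alone. Nothing measured here accounts for these numbers.

From the compounds shown here alone, whether a primary amine or a carboxylic acid on this carbonyl carbon would stay with compound 2 and compound 3 or fall toward compound 1 remains open. So does the outcome for a longer acyl chain in place of isopropylcarbonyl.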